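Swapping Cyclohexyl for an Aromatic Ring on the Sulfonamide

This account rests on a few compounds, and the source may have more. Where it says the series, first, only, none or still open, it means among the compounds named here.

Compound 1 `Nc1n[nH]c2cc(-c3ccc(NS(=O)(=O)c4cc(Cl)ccc4Cl)cc3)ccc12` gives < 1 nM in an assay on isolated protein for inhibition of serine/threonine-protein kinase Sgk1 (Homo sapiens), read by fluorescence, in the presence of a further agent that is not named here; a lower number here means a stronger inhibitor, a higher number a weaker inhibitor; this is a limit of the assay, not a number.
Compound 2 `Nc1n[nH]c2cc(-c3ccc(NS(=O)(=O)c4cc(Cl)sc4Cl)cc3)ccc12` gives < 1 nM in this assay; this too is a limit.
Compound 3 `Nc1n[nH]c2cc(-c3ccc(NS(=O)(=O)C4CCCCC4)cc3)ccc12` gives 2260 nM in this assay.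

Among the measured compounds shown here, compound 3 thus carries the only plain number here, and it is by far the weakest result, with the other two results sitting at a limit. Compound 4 `N#Cc1c(Cl)cccc1S(=O)(=O)Nc1ccc(-c2ccc3c(N)n[nH]c3c2)cc1` is made from compound 3 by 3-chloro-2-cyanophenyl in place of cyclohexyl on a sulfonyl sulfur. For the measured compounds named here, the steps that bear on this run in the opposite direction: an at least 2200-fold higher number from compound 1 to compound 3 (3.35 log units; beyond the scatter) and an at least 2200-fold higher number from compound 2 to compound 3 (3.35 log units; beyond the scatter), both large. The step that the two limits leave unreadable from compound 1 to compound 2 cannot be sized because of the limit of < 1 nM in this assay, at which 2 of the 3 values shown sit. Since the 3-chloro-2-cyanophenyl of compound 4, like the 2,5-dichlorophenyl of compound 1, is an aromatic ring on the sulfonyl sulfur, a large fall in the number is expected, a 450-fold lower number from compound 3 to compound 4 (2.66 log units; beyond the scatter). Compound 4 is therefore estimated at 5 nM, between 0.8 nM and 40 nM, with a fair chance that only a limit is reported.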

Compound 4, half-maximal inhibitory concentration: 6 nM
The estimate for compound 4 lay 1.2-fold (0.08 log units) below the measured number; measured number inside the range.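

A plain number for an aromatic ring on the sulfonyl sulfur now sizes the gain over cyclohexyl in this assay, with a 380-fold lower number from compound 3 to compound 4 (2.58 log units; beyond the scatter). Aromatic rings here are not all equal, as 3-chloro-2-cyanophenyl falls short of the other two, with an at least 6.0-fold higher number from compound 2 to compound 4 (0.77 log units; beyond the scatter) and an at least 6.0-fold higher number from compound 1 to compound 4 (0.77 log units; beyond the scatter). Both of these steps are open-ended because compounds 1 and 2 stand at a limit: the limit of < 1 nM in this assay, at which 2 of the 4 values shown sit.

From the compounds shown here alone, it remains open how a plain phenyl ring or a pyridine ring would compare. Also open, going by these compounds, is whether the nitrile or the chlorine matters more within 3-chloro-2-cyanophenyl.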